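The source may report more compounds than this note shows. Statements on the series, on what has been measured and on what is new or still open speak of the compounds shown alone.

Two compounds of the series carry a number in an assay on LtK cells with ATP-sensitive inward rectifier potassium channel 11 (Homo sapiens) as the target; a higher number here means that more compound is needed for the effect, a lower number that less compound is needed. Compound 1 `CC(C)=CC(=O)Nc1c(C(O)(C(F)(F)F)C(F)(F)F)ccc2ccccc12` gives 46 nM, and compound 2 `COCC(=O)Nc1c(C(O)(C(F)(F)F)C(F)(F)F)ccc2ccccc12` gives 213 nM. Within the data shown here, the only measured step is a 4.6-fold higher number from compound 1 to compound 2 (0.67 log units; beyond the scatter). Compound 2 therefore stands with the higher of the two numbers in this assay.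

Compound 3 `CC(C)OC(=O)Nc1c(C(O)(C(F)(F)F)C(F)(F)F)ccc2ccccc12` is obtained from compound 2 by isopropoxy in place of methoxymethyl on a carbonyl carbon. Among the measured compounds shown here, no measured step bears directly on an isopropoxy group at this carbonyl carbon. For the measured compounds named here, the one step measured, a 4.6-fold higher number from compound 1 to compound 2 (0.67 log units; beyond the scatter), concerns a different group at the same carbonyl carbon and shows only that a change there can move this assay beyond the scatter. With nothing closer to go on, compound 3 is expected to remain near compound 2. The expected step of a 1.4-fold lower number from compound 2 to compound 3 (0.15 log units; within the scatter) is small, with its direction left open. The estimate for compound 3 in this assay is 150 nM, within a range of 50 nM to 450 nM.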

Compound 3, half-maximal effective concentration: 1160 nM
The estimate for compound 3 lay 7.7-fold (0.89 log units) below the measured number, and the stated range ends below it.
By their numbers in this assay, from the lowest: compound 1; then compound 2; then compound 3.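

At this carbonyl carbon, isopropoxy in place of methoxymethyl gives a 5.4-fold higher number from compound 2 to compound 3 (0.74 log units; beyond the scatter) in this assay and so adds a second change at this position that moves the number beyond the scatter. Isopropoxy in place of 2-methylprop-1-en-1-yl gives a 25-fold higher number from compound 1 to compound 3 (1.40 log units; beyond the scatter) and is the largest step in the set, with all three groups now separated beyond the scatter and 2-methylprop-1-en-1-yl carrying the lowest number.

The compounds shown leave open whether a methoxy or tert-butoxy group at this carbonyl carbon would stay close to isopropoxy, and whether an amine such as dimethylamino would behave in the same way. They also leave open whether the saturated 2-methylpropyl chain would stay near compound 1 or move towards compound 2. No measurement at hand gives a reason for these steps.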